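Shared core series: ether side chain and cytotoxicity

This account rests on a few compounds, and the source may have more. Where it says the series, first, only, none or still open, it means among the compounds named here.

Going by the values given here, compound 2 `CCC1(Cc2ccccc2)OS(=O)(=O)C=C1OCCCc1ccccc1` holds the higher of the pair of numbers measured so far in an ADME assay on HEL cells (Homo sapiens) for cytotoxicity, with a stated time of 3 days; a higher number here means that more compound is tolerated, a lower number that less compound is tolerated: compound 2 gives 133000 nM, whereas compound 1 `CCC1(Cc2ccccc2)OS(=O)(=O)C=C1OCc1ccccc1Cl` gives 38000 nM. Among the compounds with values here, the single measured step, a 3.5-fold higher number from compound 1 to compound 2 (0.54 log units; beyond the scatter), moved the read-out upward by a modest amount and lay beyond the scatter. Compound 3 `CCC1(Cc2ccccc2)OS(=O)(=O)C=C1OCc1ccccc1` differs from compound 2 by phenyl in place of phenethyl on a saturated chain carbon bound to an oxygen on an unsaturated carbon. Within the data shown here, this varies the same position as the measured step, but it is not the same exchange, since neither measured compound carries a plain phenyl there; no measured step maps onto it directly. Because the position already gave a 3.5-fold higher number from compound 1 to compound 2 (0.54 log units; beyond the scatter), a step of comparable size is plausible, and a modest downward move, a 1.9-fold lower number from compound 2 to compound 3 (0.28 log units; within the scatter), is expected, placing compound 3 between the measured values. Compound 3 is estimated at 70000 nM in this assay, with a range of 30000 nM to 160000 nM.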

Compound 3, half-maximal cytotoxic concentration: 200000 nM
For compound 3 the middle estimate is 2.9-fold (0.46 log units) below the measured one; the whole stated range lies below it.
By their numbers in this assay, from the lowest: compound 1; then compounds 2 and 3 (each within the scatter of the next).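

In this assay the exchange of phenethyl for phenyl on a saturated chain carbon bound to an oxygen on an unsaturated carbon gives a 1.5-fold higher number from compound 2 to compound 3 (0.18 log units; within the scatter) and does not separate the two compounds, so this chain change shows no readable effect here. Hydrogen in place of chloro on an aromatic carbon gives a 5.3-fold higher number from compound 1 to compound 3 (0.72 log units; beyond the scatter) as a single change, which ties the separation of compound 1 from compound 3 to the chloro, carried by compound 1 alone of the three. Nothing on hand explains either step.

As far as these compounds go, whether fluoro, methoxy or an amine in place of chloro on an aromatic carbon gives a step of similar size stays open. Also open, from the compounds shown here alone, are whether a longer chain at the ether position stays level with compound 2 and compound 3, and whether the chloro step holds on a phenethyl side chain.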